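The source may hold more compounds than are shown below. What is called first, only, known or untested is meant among the compounds shown, and "the series" means these compounds.

Measured compounds:
compound 1, `CCCc1nc(-c2ccccc2)c(CNCCN2CCN(c3cccc(C(F)(F)F)c3)CC2)o1`: 1940 nM
compound 2, `CCCc1nc(-c2ccccc2)c(CNCCCN2CCN(c3ccc(F)cc3)CC2)o1`: 3210 nM
compound 3, `CCCc1nc(-c2ccccc2)c(CNCCN2CCN(c3ccccc3C)CC2)o1`: 4300 nM

All three share one core and differ at the aryl group on the amine nitrogen of the ring, and in an assay on HEK293 cells for inhibition of Voltage-dependent T-type calcium channel subunit alpha-1G (Homo sapiens), read by patch clamp (a lower number here means a stronger inhibitor, a higher number a weaker inhibitor), they lie close together. Compound 2 gives 3210 nM, a number that neither compound 1 nor compound 3 separates from beyond the scatter. For the measured compounds named here, the only change measured in one place is a 2.2-fold higher number from compound 1 to compound 3 (0.35 log units; beyond the scatter), and that swap exchanges a whole aryl group, whereas compound 4, `CCCc1nc(-c2ccccc2)c(CNCCCN2CCN(c3ccc(Cl)cc3)CC2)o1`, differs from compound 2 in a single atom: chloro in place of fluoro on an aromatic carbon. Going by the values given here, no measured step exchanges one halogen for another, so the step from compound 1 to compound 3 bears on it only as a guide to how little this part of the molecule moves the numbers. Compound 4 is therefore expected to give 2600 nM, in a range of 1200 nM to 5500 nM. The expected step of a 1.2-fold lower number from compound 2 to compound 4 (0.09 log units; within the scatter) is estimated to stay within the scatter.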

Compound 4, half-maximal inhibitory concentration: 1310 nM
Compound 4: middle estimate off by 2.0-fold (0.30 log units), on the high side, within the range that was stated.
By their numbers in this assay, from the lowest: compounds 4, 1, 2 and 3 (each within the scatter of the next, the first and the last beyond it).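

The 4-fluorophenyl to 4-chlorophenyl change shows that this position responds to a single atom: in this assay, chloro in place of fluoro on an aromatic carbon, para to a large group, gives a 2.5-fold lower number from compound 2 to compound 4 (0.39 log units; beyond the scatter) and so passes beyond the scatter. For the compounds shown here, the only earlier step read in one place, a 2.2-fold higher number from compound 1 to compound 3 (0.35 log units; beyond the scatter), exchanged a whole aryl group, so a change of one halogen moves the number here more clearly than the earlier compounds suggested. Nothing shown here explains the difference between the two halogens.

From the compounds shown here alone, it remains open whether bromo or methoxy in this place would give a lower or a higher number than chloro. Going by these compounds, it is also open whether the same exchange would give a similar step on the shorter chain of compound 1 and compound 3.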